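The source may hold more compounds than are shown below. What is called first, only, known or untested is meant among the compounds shown, and "the series" means these compounds.

Working notes on the series. In a functional assay on U-937 cells (Homo sapiens) for antiproliferative activity, read by MTT assay, with a stated time of 24 h (on this read-out higher numbers stand for weaker inhibition and lower numbers for stronger inhibition), compound 1 (`Cc1cccc(Nc2ncc(Br)c(Oc3cccc(F)c3)n2)c1`) gives 19400 nM and compound 2 (`COc1cc(Nc2ncc(I)c(NCCCN)n2)cc(OC)c1OC`) gives 39900 nM. Compound 2 therefore holds the higher of the two numbers, meaning the weaker inhibition, and its gap to compound 1 lies beyond the scatter. These two compounds differ in more than one place, so the gap cannot be assigned to any single group. Compound 3 (`CCN(CC)CCNc1nc(Nc2cc(OC)c(OC)c(OC)c2)ncc1I`) keeps the core of compound 2 and carries diethylamino in place of aminomethyl on a saturated chain carbon, two bonds along the chain from a nitrogen on an aromatic ring. Among the compounds with values here, no measured pair shows this change, so the expectation is loose. A modest move towards stronger inhibition in this assay is expected, with an estimated 2.0-fold lower number from compound 2 to compound 3 (0.30 log units; within the scatter). For compound 3 the estimated value is 20000 nM, with an expected range of 7000 nM to 55000 nM.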

Compound 3, half-maximal inhibitory concentration: 22000 nM
For compound 3 the middle estimate is 1.1-fold (0.04 log units) below the measured one; measured number inside the range.
By their numbers in this assay, from the lowest: compounds 1, 3 and 2 (each within the scatter of the next, the first and the last beyond it).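

In this assay the series gains its first one-place comparison: diethylamino in place of aminomethyl on a saturated chain carbon, two bonds along the chain from a nitrogen on an aromatic ring, gives a 1.8-fold lower number from compound 2 to compound 3 (0.26 log units; within the scatter) and does not separate the two compounds. This place therefore accepts diethylamino, with 5 heavy atoms and 0 hydrogen-bond donors, in place of aminomethyl, with 2 heavy atoms and 1 hydrogen-bond donor, without a step beyond the scatter. No measurement at hand accounts for this result.

The compounds shown leave open whether a morpholine or piperidine ring, or a longer chain, at this place would give a step beyond the scatter. Also open, on these data alone, is how bromine in place of iodine on the core of compound 3 would read.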